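From pyridin-2-yl to pyridin-3-yl on a shared core

A few compounds are considered here, and "the series" means these few. Any claim that something is new, unique, unknown or untested is made for them only; others in the source may bear on it.

Compound 1 `Oc1cccc(-c2cc(-c3cccs3)cc(-c3cccc(O)c3)n2)c1` gives 1630 nM in a functional assay on DU-145 cells (Homo sapiens) for cytotoxicity, read by CCK-8 assay; on this read-out higher numbers stand for weaker inhibition and lower numbers for stronger inhibition.
Compound 2 `Oc1cccc(-c2cc(-c3ccsc3)cc(-c3cccc(O)c3)n2)c1` gives 1310 nM in this assay.
Compound 3 `Oc1cccc(-c2cc(-c3ccccn3)cc(-c3cccc(O)c3)n2)c1` gives 3610 nM in this assay.

Compound 3 holds the highest number of the three: the steps of a 2.2-fold higher number from compound 1 to compound 3 (0.35 log units; beyond the scatter) and a 2.8-fold higher number from compound 2 to compound 3 (0.44 log units; beyond the scatter) both lie beyond the scatter, so compound 3 is the weakest inhibitor shown. Compound 4 `Oc1cccc(-c2cc(-c3cccnc3)cc(-c3cccc(O)c3)n2)c1` differs from compound 3 by pyridin-3-yl in place of pyridin-2-yl on an aromatic carbon. Among the compounds with values here, the one comparable step, a 1.2-fold lower number from compound 1 to compound 2 (0.09 log units; within the scatter), swapped the attachment point of a five-membered ring and stayed within the scatter, which suggests that moving the attachment point of the pyridyl ring matters little. A step within the scatter is therefore expected in this assay, perhaps slightly toward lower numbers, as a 1.2-fold lower number from compound 3 to compound 4 (0.08 log units; within the scatter). Compound 4 is estimated at 3000 nM, between 1500 nM and 6000 nM.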

Compound 4, half-maximal inhibitory concentration: > 50000 nM
Compound 4: a limit, no number (the forecaster's own chance of this, stated with the estimate: 5%); middle value at least 16-fold (1.22 log units) away from the limit.
By their numbers in this assay, from the lowest: compounds 2 and 1 (each within the scatter of the next); then compound 3. At a limit, above all of these: compound 4.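

Compound 4 sits at a limit of this assay, not at a number: the limit of > 50000 nM in this assay, at which 1 of the 4 values shown sits. At this position, the place of the ring nitrogen can matter greatly, although the group keeps the same atoms, as shown by an at least 13-fold higher number from compound 3 to compound 4 (1.14 log units; beyond the scatter). Compound 4 is also the weakest inhibitor shown, with an at least 38-fold higher number from compound 2 to compound 4 (1.58 log units; beyond the scatter) and an at least 30-fold higher number from compound 1 to compound 4 (1.48 log units; beyond the scatter). The compounds shown leave open how pyridin-4-yl would behave here. They also do not show whether a phenyl ring carrying an amine would stand nearer compound 3 or compound 4.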